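The compounds below may be only part of what the source reports. "The series", "measured", "known", "first", "only" and "open" are said of these compounds alone.

Compound 1 `CCCCC[Se]c1nc(NCc2ccccc2)c2ccccc2n1` and compound 3 `C[Se]c1nc(NCc2ccccc2)c2ccccc2n1` share one core, while compound 2 `CCCCC[Se]c1nc(N)c2cccnc2n1` and the still unmeasured compound 4 `C[Se]c1nc(N)c2cccnc2n1` share another; the difference between the two cores is not broken down here. In a functional assay on HTB-54 cells (Homo sapiens) for cytotoxicity, read by MTT assay, with a stated time of 72 h (a lower number here means a stronger inhibitor of growth, a higher number a weaker inhibitor of growth), compound 1 gives 37700 nM, and compound 3 gives 74600 nM. The change that separates them, (hydrogen in place of butyl on a saturated chain carbon bound to a selenium atom), produced a 2.0-fold higher number from compound 1 to compound 3 (0.30 log units; within the scatter). In this assay compound 2 gives 8780 nM, the lowest of the three numbers and beyond the scatter from both others. Compound 4 carries the same change relative to compound 2, (hydrogen in place of butyl on a saturated chain carbon bound to a selenium atom). The step is expected to be a 1.7-fold higher number from compound 2 to compound 4 (0.23 log units; within the scatter), resting on what was seen in a 2.0-fold higher number from compound 1 to compound 3 (0.30 log units; within the scatter). Compound 4 is therefore estimated at 15000 nM, with a plausible range from 6000 nM to 40000 nM.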

Compound 4, concentration for 50% growth inhibition: 78200 nM
Compound 4: the middle estimate sits 5.2-fold (0.72 log units) below what was measured; measured number above the stated range.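

In this assay, placing hydrogen in place of butyl on a saturated chain carbon bound to a selenium atom gave an 8.9-fold higher number from compound 2 to compound 4 (0.95 log units; beyond the scatter). The size of this step did not carry over from one core to the other: the same change on two cores in this assay, a 2.0-fold higher number (0.30 log units; within the scatter) from compound 1 to compound 3 and an 8.9-fold higher number (0.95 log units; beyond the scatter) from compound 2 to compound 4, 4.5-fold (0.65 log units) apart, beyond the scatter of two such steps

This shows that, for these two pairs, the effect of the change differs with the core, but it does not show which feature of the cores matters or how the change would behave on a further core. The compounds shown leave open where a propyl chain in place of the pentyl would fall on either core, and whether the two cores would still differ with that chain.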